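Removing the aryl group from compound 1's triazole

A few compounds are considered here, and "the series" means these few. Any claim that something is new, unique, unknown or untested is made for them only; others in the source may bear on it.

Going by the values given here, compound 1 `COc1ccc(-c2cn(C[C@H](O)[C@H]3OC(=O)C(OCc4ccccc4)=C3OCc3ccccc3)nn2)cc1` is the only member of this set with a number in a functional assay on CFPAC-1 cells (Homo sapiens) for antiproliferative activity, read by MTT assay, with a stated time of 72 h; on this read-out higher numbers stand for weaker inhibition and lower numbers for stronger inhibition; in it compound 1 gives 26000 nM. Compound 2 `O=C1O/C(=C\Cn2cc(-c3ccc(Br)cc3)nn2)C(OCc2ccccc2)=C1OCc1ccccc1` reaches only a limit, > 100000 nM. Compound 3 `CCCCCc1ccc(-c2cn(C/C=C3\OC(=O)C(OCc4ccccc4)=C3OCc3ccccc3)nn2)cc1` likewise stops at a limit, > 100000 nM. Among the compounds with values here, the one measured step, a step that the two limits leave unreadable from compound 2 to compound 3, therefore cannot be sized, and both values sit at the limit of > 100000 nM in this assay, at which 2 of the 3 values shown sit. Compound 4 `O=C1O[C@H]([C@@H](O)Cn2ccnn2)C(OCc2ccccc2)=C1OCc1ccccc1` differs from compound 1 by hydrogen in place of 4-methoxyphenyl on an aromatic carbon. Within the data shown here, no measured step touches this change, so its size is unknown; the account expects the step of a 2.7-fold higher number from compound 1 to compound 4 (0.43 log units; beyond the scatter) to run toward weaker inhibition, with a fair chance of a limit. Compound 4 is therefore estimated at 70000 nM, within 25000 nM to 200000 nM.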

Compound 4, half-maximal inhibitory concentration: > 100000 nM
Compound 4 was reported as a limit; the forecaster's own chance of this, stated with the estimate: 45%; middle value at least 1.4-fold (0.15 log units) from the limit.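

Hydrogen in place of 4-methoxyphenyl on this aromatic carbon gives the first readable step in this assay, an at least 3.8-fold higher number from compound 1 to compound 4 (0.58 log units; beyond the scatter). The measurable inhibition of compound 1 is therefore lost when this aryl group is removed, which the unreadable step between compounds 2 and 3 could not show. The size remains a minimum, as compound 4 stands at a limit: the limit of > 100000 nM in this assay, at which 3 of the 4 values shown sit.

The compounds shown leave open whether a small group such as methyl on this carbon would retain inhibition. On these data alone, it also remains open whether an amine or a carboxylic acid in place of the methoxy group would do so.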